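This account rests on a few compounds, and the source may have more. Where it says the series, first, only, none or still open, it means among the compounds named here.

Three compounds of the series carry measurements in a functional assay (Oryctolagus cuniculus) for inhibition of platelet-activating factor receptor (Cavia porcellus); a higher number here means a weaker inhibitor, a lower number a stronger inhibitor. Compound 1 `CCCCCCCCCCCCCCCCCC(=O)OCC1CN(C(=O)c2cc(OC)c(OC)c(OC)c2)CCN1C(=O)c1cc(OC)c(OC)c(OC)c1` gives 45000 nM. Compound 3 `CCC(CC)C(=O)OCC1CN(Cc2cc(OC)c(OC)c(OC)c2)CCN1Cc1cc(OC)c(OC)c(OC)c1` gives 2700 nM. Compound 2 `COc1cc(C(=O)N2CCN(C(=O)c3cc(OC)c(OC)c(OC)c3)C(COC(=O)CC(C)(C)C)C2)cc(OC)c1OC` gives 120 nM, the lowest of the three numbers; its gaps to compound 3 and to compound 1 both lie beyond the scatter, so compound 2 is the strongest inhibitor measured so far. Compound 4 `COc1cc(C(=O)N2CCN(C(=O)c3cc(OC)c(OC)c(OC)c3)C(COC(=O)NC(C)C(C)C)C2)cc(OC)c1OC` has not been measured. It differs from compound 2 by (1,2-dimethylpropyl)amino in place of neopentyl on a carbonyl carbon. For the measured compounds named here, no step between measured compounds isolates this change, so the expectation rests on compound 2 alone. A moderate loss is expected; the estimated step is a 2.5-fold higher number from compound 2 to compound 4 (0.40 log units; beyond the scatter), beyond the scatter but small against the range already seen. Compound 4 is therefore estimated at 300 nM, within 80 nM to 1200 nM.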

Compound 4, half-maximal inhibitory concentration: 80 nM
Beside the measured number, compound 4's estimate is 3.8-fold (0.57 log units) above it; low and high end bracket the measured number.
By their numbers in this assay, from the lowest: compounds 4 and 2 (each within the scatter of the next); then compound 3; then compound 1.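

At this position, on a carbonyl carbon, (1,2-dimethylpropyl)amino in place of neopentyl gives a 1.5-fold lower number from compound 2 to compound 4 (0.18 log units; within the scatter) in this assay. The position thus accepts a nitrogen on this carbonyl carbon, with one hydrogen-bond donor more, and the difference cannot be told from the scatter. No measurement available here bears on why the two numbers agree.

On these data alone, whether the hydrogen on that nitrogen matters remains open, and dimethylamino on the same carbonyl carbon would address this. Also open, as far as these compounds go, is how far a longer chain or a cyclohexylamino group would be accepted there.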